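The source may report more compounds than this note shows. Statements on the series, on what has been measured and on what is new or still open speak of the compounds shown alone.

Measured compounds:
Compound 1, `C=C1[C@@H](OC(C)=O)C[C@@H]2[C@](C)(CO[Si](C)(C)C(C)(C)C)[C@H](OC(C)=O)CC[C@@]2(C)[C@@H]1C[C@@H](Nc1ccccc1)C1=CCOC1=O`, gives 4050 nM in a functional assay on HT-29 cells (Homo sapiens) for cytotoxicity, read by sulforhodamine B assay; on this read-out lower numbers stand for stronger inhibition and higher numbers for weaker inhibition.
Compound 2, `C=C1[C@@H](C/C=C2/C(=O)OC[C@H]2OC(C)=O)[C@]2(C)CC[C@@H](OC(C)=O)[C@@](C)(CO[Si](C)(C)C(C)(C)C)[C@H]2C[C@@H]1O`, gives 9310 nM in this assay.
Compound 3, `C=C1[C@@H](OC(C)=O)C[C@@H]2[C@](C)(COC=O)[C@H](OC(C)=O)CC[C@@]2(C)[C@@H]1C[C@@H](Nc1ccccc1C(=O)O)C1=CCOC1=O`, gives 28700 nM in this assay.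

Among these three, compound 3 stands at the highest number, that is, it is the weakest inhibitor of the set. Its nearest neighbour is compound 2, whose number is lower by a margin beyond the usual scatter, and compound 1 lies furthest away, also beyond the scatter. Among the compounds with values here, compound 1 carries an unsubstituted phenyl on the amine nitrogen, but it differs from compound 3 in a second place as well, so no single step between the two can be read.

Compound 4, `C=C1[C@@H](OC(C)=O)C[C@@H]2[C@](C)(COC=O)[C@H](OC(C)=O)CC[C@@]2(C)[C@@H]1C[C@@H](Nc1ccc(O)cc1)C1=CCOC1=O`, is the next compound to be measured in this assay. It differs from compound 3 in one place: 4-hydroxyphenyl in place of 2-carboxyphenyl on an amine nitrogen.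

Within the data shown here, with no single-point step between measured compounds to lean on, the expectation rests on the spread of the three numbers. Compound 4 is expected to move toward the lower numbers of compound 1 and compound 2, by a step of a 2.4-fold lower number from compound 3 to compound 4 (0.38 log units; beyond the scatter), with wide uncertainty. Compound 4 is therefore estimated at 12000 nM, with a range from 4000 nM to 36000 nM.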

Compound 4, half-maximal inhibitory concentration: 13400 nM
Compound 4: the middle estimate sits 1.1-fold (0.05 log units) below what was measured; low and high end bracket the measured number.
By their numbers in this assay, from the lowest: compound 1; then compounds 2 and 4 (each within the scatter of the next); then compound 3.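

Within the data shown here, on the amine nitrogen, the exchange of 2-carboxyphenyl for 4-hydroxyphenyl gives the first single change that can be read in this assay, with a 2.1-fold lower number from compound 3 to compound 4 (0.33 log units; beyond the scatter) on the shared core. This shows that the position responds to what the aromatic ring carries, although the effect of this change is modest and both compounds remain in the weaker part of the set. The ring itself stays the same and the hydrogen-bond donor and acceptor counts of the two groups match, so the step is tied to a swap of substituent and place on that ring, and nothing measured here explains it.

One step cannot separate the loss of the carboxylic acid from the gain of the hydroxyl, nor the effect of the group's identity from that of its place on the ring. On these data alone, whether 4-carboxyphenyl or 2-hydroxyphenyl on the same nitrogen would follow this step, or whether a methoxy group or an amine on the ring would carry it further, stays open.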